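The source may hold more compounds than are shown below. What is called first, only, known or untested is meant among the compounds shown, and "the series" means these compounds.

Going by the values given here, compound 1 `COc1ccc2c(=O)c(/C=C/C(=O)Nc3ccccc3Cl)coc2c1` is the one compound here with a number rather than a limit: in a functional assay on HeLa cells (Homo sapiens) for inhibition, read by MTT assay, with a stated time of 48 h (a higher number here means a weaker inhibitor, a lower number a stronger inhibitor), compound 1 gives 22400 nM. Two companions sit on a hydroxy-bearing core with benzyl amides. In this assay compound 2 `O=C(/C=C/c1coc2cc(O)ccc2c1=O)NCc1ccc(F)cc1` gives > 100000 nM, which is a limit of the assay. In this assay compound 3 `Cc1ccc(CNC(=O)/C=C/c2coc3cc(O)ccc3c2=O)cc1` gives > 100000 nM, likewise a limit. Among the compounds with values here, the one single-point step, a step that the two limits leave unreadable from compound 2 to compound 3, is therefore of unreadable size, as the limit of > 100000 nM in this assay, at which 2 of the 3 values shown sit, shows.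

Compound 4 `COc1ccc2c(=O)c(/C=C/C(=O)NCc3ccc(F)cc3F)coc2c1` keeps the methoxy core of compound 1 and changes the amide substituent: 2,4-difluorobenzyl in place of 2-chlorophenyl on an amide-type nitrogen. Within the data shown here, no measured step covers this change directly; compounds 2 and 3 differ from compound 4 in two places, and their two limits show only that benzyl amides on the hydroxy core stayed above the range of this assay. The expectation is therefore a loss, a 2.2-fold higher number from compound 1 to compound 4 (0.35 log units; beyond the scatter), with a real chance that compound 4 too returns only a limit. Compound 4 is estimated at 50000 nM, between 15000 nM and 150000 nM.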

Compound 4, half-maximal inhibitory concentration: > 100000 nM
Compound 4 was reported as a limit; the forecaster's own chance of this, stated with the estimate: 40%; middle value at least 2.0-fold (0.30 log units) away from the limit.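

On the shared core, 2,4-difluorobenzyl in place of 2-chlorophenyl on an amide-type nitrogen gives an at least 4.4-fold higher number from compound 1 to compound 4 (0.64 log units; beyond the scatter) in this assay. Going by these compounds alone, the earlier step from compound 2 to compound 3 cannot be read, so this is the first sign that the group on this nitrogen changes the result, and it rests on a limit, as compound 4 gives > 100000 nM, which is a limit of the assay and not a number. The true size of the step therefore stays unknown: the limit of > 100000 nM in this assay, at which 3 of the 4 values shown sit.

On these data alone, what a 2-chlorobenzyl, a plain phenyl or a 2,4-difluorophenyl group would give on that nitrogen remains open, and with it whether the benzyl or the halogens carry the step. Also open, as far as these compounds go, is how a group with an amine or a carboxylic acid would read at this place.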